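From carbamoyl to propylcarbamoyl on a shared core

The source may hold more compounds than are shown below. What is called first, only, known or untested is meant among the compounds shown, and "the series" means these compounds.

Among the measured compounds shown here, in a functional assay on Huh-7 cells (Homo sapiens) for antiproliferative activity, read by CCK-8 assay, with a stated time of 72 h (a higher number here means a weaker inhibitor of growth, a lower number a stronger inhibitor of growth), compound 1 (`CC[C@@H]1C(=O)N(C)c2cnc(-n3ccc4cc(C(N)=O)ccc43)nc2N1C1CCCC1`) gives 3090 nM, the lowest of the three numbers measured so far. Compound 3 (`CCCNC(=O)c1ccc2c(ccn2-c2ncc3c(n2)N(c2ccn(C)n2)C(CC)C(=O)N3C)c1`) gives 7280 nM and compound 2 (`CCC1C(=O)N(C)c2cnc(-n3ccc4cc(C(=O)NC)ccc43)nc2N1c1ccn(C)n1`) gives 13200 nM, and both also differ from compound 1 on the core. Compound 4 (`CCCNC(=O)c1ccc2c(ccn2-c2ncc3c(n2)N(C2CCCC2)[C@H](CC)C(=O)N3C)c1`) keeps the core of compound 1 and changes only the amide: propyl in place of hydrogen on an amide-type nitrogen, which is propyl in place of hydrogen on an amide-type nitrogen. For the measured compounds named here, the one measured step that bears on this is a 1.8-fold lower number from compound 2 to compound 3 (0.26 log units; within the scatter), which lies within the scatter. It extends the chain on the same amide, with ethyl in place of hydrogen on a saturated chain carbon bound to an amide-type nitrogen, but it does so on a different core and does not start from carbamoyl. No step beyond the scatter is therefore expected in this assay, and the estimated change is a 1.2-fold lower number from compound 1 to compound 4 (0.09 log units; within the scatter). Compound 4 is expected at about 2500 nM, within an estimated range of 900 nM to 7000 nM.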

Compound 4, concentration for 50% growth inhibition: 689 nM
The estimate for compound 4 lay 3.6-fold (0.56 log units) above the measured number; the measured number lies below the stated range.
By their numbers in this assay, from the lowest: compound 4; then compound 1; then compounds 3 and 2 (each within the scatter of the next).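

On the core of compound 1, propyl in place of hydrogen on an amide-type nitrogen produces a step beyond the scatter in this assay, namely a 4.5-fold lower number from compound 1 to compound 4 (0.65 log units; beyond the scatter), the first change on this amide shown to move the number by more than the scatter. Among the compounds shown here, the only earlier step on this amide, a 1.8-fold lower number from compound 2 to compound 3 (0.26 log units; within the scatter), lengthened an existing chain on a different core and stayed within the scatter, so the present step adds a case in which the unsubstituted carbamoyl gives way to propylcarbamoyl. Nothing measured in this account explains why the number falls.

As far as these compounds go, it remains open whether propyl is the best choice on this nitrogen, or whether a longer chain, a branched chain such as isopropyl, or a chain ending in an amine would lower the number further. From the compounds shown here alone, it also remains open whether going from carbamoyl to propylcarbamoyl gives a step of this size on the core of compound 3.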